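Heteroaryl swap at the biphenyl position of compound 3

The source may report more compounds than this note shows. Statements on the series, on what has been measured and on what is new or still open speak of the compounds shown alone.

Within the data shown here, compound 3 `Cc1ccc(C)n1-c1cccc(COc2ccc(S(=O)(=O)CC(=O)O)cc2)c1` stands second highest of the three numbers so far: in a functional assay on CHO cells for agonist activity at Free fatty acid receptor 1 (Homo sapiens), read by FLIPR and calcium flux (a lower number here means that less compound is needed, a higher number that more compound is needed for the effect), compound 3 gives 129 nM. Its nearest neighbour is compound 1 `O=C(O)CS(=O)(=O)c1ccc(OCc2cccc(-c3ccccc3C(F)(F)F)c2)cc1`, which in this assay gives 52.5 nM, the step being a 2.5-fold higher number from compound 1 to compound 3 (0.39 log units; beyond the scatter). Furthest is compound 2 `N#Cc1ccccc1-c1cccc(COc2ccc(S(=O)(=O)CC(=O)O)cc2)c1`, which in this assay gives 457 nM; that step is a 3.5-fold lower number from compound 2 to compound 3 (0.55 log units; beyond the scatter). The remaining step, an 8.7-fold higher number from compound 1 to compound 2 (0.94 log units; beyond the scatter), concerns the same position.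

Compound 4 `Cc1noc(C)c1-c1cccc(COc2ccc(S(=O)(=O)CC(=O)O)cc2)c1` differs from compound 3 in one place: 3,5-dimethyl-1,2-oxazol-4-yl in place of 2,5-dimethyl-1H-pyrrol-1-yl on an aromatic carbon. Among the measured compounds shown here, no measured step covers this change; the two steps that touch this position, a 2.5-fold higher number from compound 1 to compound 3 (0.39 log units; beyond the scatter) and a 3.5-fold lower number from compound 2 to compound 3 (0.55 log units; beyond the scatter), show that changes there have stayed modest in either direction. The expectation is therefore a modest step, most likely a somewhat higher number in this assay, estimated as a 1.7-fold higher number from compound 3 to compound 4 (0.23 log units; within the scatter). Compound 4 is estimated at 220 nM, with a range from 70 nM to 700 nM.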

Compound 4, half-maximal effective concentration: 269 nM
Compound 4: the middle estimate sits 1.2-fold (0.09 log units) below what was measured; low and high end bracket the measured number.
By their numbers in this assay, from the lowest: compound 1; then compound 3; then compounds 4 and 2 (each within the scatter of the next).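

In this assay, the swap between two five-membered aromatic rings of equal heavy-atom count, 2,5-dimethyl-1H-pyrrol-1-yl to 3,5-dimethyl-1,2-oxazol-4-yl, gives a 2.1-fold higher number from compound 3 to compound 4 (0.32 log units; beyond the scatter), so the position responds even to this close exchange. Set against the two substituted phenyl groups, 3,5-dimethyl-1,2-oxazol-4-yl shows a 1.7-fold lower number from compound 2 to compound 4 (0.23 log units; within the scatter) and a 5.1-fold higher number from compound 1 to compound 4 (0.71 log units; beyond the scatter), leaving it level with 2-cyanophenyl within the scatter and well apart from 2-(trifluoromethyl)phenyl, which still gives the lowest number of the four. No available evidence explains these differences.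

The two five-membered groups differ in both ring hetero atoms and point of attachment, and the compounds shown do not separate these two changes. Also open, on these data alone, is how the number responds to an amine, a carboxylic acid or a longer chain at this position.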